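The source may report more compounds than this note shows. Statements on the series, on what has been measured and on what is new or still open speak of the compounds shown alone.

Measured in a functional assay on MCF7 cells (Homo sapiens) for cytotoxicity, read by MTT assay, with a stated time of 96 h; on this read-out lower numbers stand for stronger inhibition and higher numbers for weaker inhibition:
compound 1 `COc1cc(C(=O)c2cn(-c3ccc(N)cc3)cc2-c2ccccc2)cc(OC)c1OC`: 35 nM
compound 2 `COc1cc(C(=O)c2cn(-c3cccc(C)c3)cc2-c2ccc(N)cc2)cc(OC)c1OC`: 18 nM
compound 3 `COc1cc(C(=O)c2cn(-c3ccc(N)cc3)cc2-c2ccccc2[N+](=O)[O-])cc(OC)c1OC`: 53 nM

Within the data shown here, compound 3, at 53 nM, has the highest of the three numbers, but it is not separated from compound 1, as the one measured single-place step shows: a 1.5-fold higher number from compound 1 to compound 3 (0.18 log units; within the scatter). That step is nitro in place of hydrogen on an aromatic carbon. Only compound 2 gives a number clearly lower than compound 3.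

The next compound is compound 4 `COc1cc(C(=O)c2cn(-c3ccc(N)cc3)cc2-c2ccc(N)cc2)cc(OC)c1OC`, with the change (4-aminophenyl in place of 2-nitrophenyl on an aromatic carbon), that is, 4-aminophenyl in place of 2-nitrophenyl on an aromatic carbon. Among the measured compounds shown here, no measured step isolates this change. The nearest evidence is compound 2, which carries 4-aminophenyl on that same aromatic carbon, with a different group elsewhere, and gives 18 nM. A lower number is therefore expected in this assay, though this rests on a single compound. The expected step is a 2.7-fold lower number from compound 3 to compound 4 (0.42 log units; beyond the scatter). For compound 4 the estimated value is 20 nM, with an expected range of 7 nM to 55 nM.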

Compound 4, half-maximal inhibitory concentration: 15 nM
Compound 4: the middle estimate sits 1.3-fold (0.12 log units) above what was measured, within the range that was stated.
By their numbers in this assay, from the lowest: compounds 4, 2, 1 and 3 (each within the scatter of the next, the first and the last beyond it).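

In this assay, a 3.5-fold lower number from compound 3 to compound 4 (0.55 log units; beyond the scatter) gives this aromatic carbon a step beyond the scatter, and a 2.3-fold lower number from compound 1 to compound 4 (0.37 log units; beyond the scatter) shows that amino in place of hydrogen on the phenyl there also moves the number beyond the scatter, unlike the nitro step, a 1.5-fold higher number from compound 1 to compound 3 (0.18 log units; within the scatter). With 4-aminophenyl on that carbon, the group on the aromatic nitrogen does not separate the two compounds: a 1.2-fold lower number from compound 2 to compound 4 (0.08 log units; within the scatter). Nothing available accounts for the lower number that comes with 4-aminophenyl at this position.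

Still open, going by these compounds, is whether a hydroxy or dimethylamino group in place of the amino group on 4-aminophenyl would keep the lower number. Also open, on these data alone, is how an unsubstituted phenyl on the aromatic nitrogen would compare with 4-aminophenyl and 3-methylphenyl.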